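Trimming the amide substituent on the indole-bearing core

This account rests on a few compounds, and the source may have more. Where it says the series, first, only, none or still open, it means among the compounds named here.

The series studied here shares one core, varied only at a single aromatic position. Compound 1, `CC[C@@H]1C(=O)N(C)c2cnc(-n3ccc4cc(F)ccc43)nc2N1C1CCCC1`, carries fluoro there and gives 16000 nM in a functional assay on Huh-7 cells (Homo sapiens) for antiproliferative activity, read by CCK-8 assay, with a stated time of 72 h; on this read-out lower numbers stand for stronger inhibition of growth and higher numbers for weaker inhibition of growth. Compound 2, `CC[C@@H]1C(=O)N(C)c2cnc(-n3ccc4cc(C(=O)NC5CCCC5)ccc43)nc2N1C1CCCC1`, carries cyclopentylcarbamoyl at the same place and gives 259 nM in this assay. Going by the values given here, the step of a 62-fold lower number from compound 1 to compound 2 (1.79 log units; beyond the scatter) is the only comparison measured so far, and it places compound 2 at the lower of the two numbers, well apart from compound 1.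

Compound 3, `CC[C@@H]1C(=O)N(C)c2cnc(-n3ccc4cc(C(N)=O)ccc43)nc2N1C1CCCC1`, keeps the carbamoyl group but not its cyclopentyl part: hydrogen in place of cyclopentyl on an amide-type nitrogen. Among the compounds with values here, no measured step touches this amide-type nitrogen directly; the one step in hand shows only that exchanging fluoro for the whole cyclopentylcarbamoyl group moved the number far, without separating the share of the amide from that of the cyclopentyl. Compound 3 is therefore expected to sit somewhat higher than compound 2, with a step of about a 3.9-fold higher number from compound 2 to compound 3 (0.59 log units; beyond the scatter) estimated, and the estimate for compound 3 is 1000 nM, within a range from 300 nM to 4000 nM.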

Compound 3, concentration for 50% growth inhibition: 3090 nM
Compound 3: the middle estimate sits 3.1-fold (0.49 log units) below what was measured; the range from low to high includes it.
By their numbers in this assay, from the lowest: compound 2; then compound 3; then compound 1.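

Going by these compounds alone, the single earlier step could not separate the amide from its cyclopentyl part, and compound 3 now divides it. In this assay, the carbamoyl group with only hydrogen on its amide-type nitrogen still improves on fluoro, with a 5.2-fold lower number from compound 1 to compound 3 (0.71 log units; beyond the scatter), so the primary amide alone accounts for a modest part of the gain, while removing cyclopentyl from that nitrogen gives a 12-fold higher number from compound 2 to compound 3 (1.08 log units; beyond the scatter), a large loss and the bigger of the two steps, which shows that most of the gain seen with compound 2 depends on the cyclopentyl group and not on the carbamoyl group alone. Nothing available here explains why either step has the size it has.

The compounds shown leave open whether the ring itself matters or whether any carbon group on this nitrogen would serve, a question that a methyl group, a longer chain such as n-butyl, or a cyclohexyl ring in place of cyclopentyl could address. They also leave open whether the carbonyl is needed at all, which a carboxylic acid or an aminomethyl group at the same aromatic carbon could begin to test.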